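The source may hold more compounds than are shown below. What is called first, only, known or untested is meant among the compounds shown, and "the series" means these compounds.

Compound 2 `COC(=O)/C=C/c1cccc(N(Cc2ccc(/C=C/c3cccc(F)c3)cc2)C(=O)C(C)C)c1` sits at the low end of the three numbers shown in an assay on isolated protein with Bile acid receptor (Homo sapiens) as the target (a lower number here means that less compound is needed, a higher number that more compound is needed for the effect), giving 71 nM. Compound 1 `COC(=O)/C=C/c1cccc(N(Cc2ccc(/C=C/c3cccc(F)c3)cc2)C(=O)C2CCCCC2)c1` gives 86 nM, and a 1.2-fold lower number from compound 1 to compound 2 (0.08 log units; within the scatter). Compound 3 `COC(=O)/C=C/c1cccc(N(Cc2ccc(/C=C/c3ccccn3)cc2)C(=O)C2CCCCC2)c1` gives 309 nM, and a 3.6-fold higher number from compound 1 to compound 3 (0.56 log units; beyond the scatter). Compound 4 `CCOc1cccc(-c2ccc(CN(C(=O)C(C)C)c3cccc(/C=C/C(=O)OC)c3)cc2)c1` is the next to be measured; it differs from compound 2 by 3-ethoxyphenyl in place of 2-(3-fluorophenyl)ethenyl on an aromatic carbon. Among the compounds with values here, no measured step makes this exact exchange. The nearest hint, the step from compound 1 to compound 3, exchanges the ring on the double-bonded chain carbon and raised the number modestly, while the step from compound 1 to compound 2, on the carbonyl carbon, stayed within the scatter. A modest rise is therefore expected. Compound 4 is estimated at 200 nM, within 50 nM to 800 nM. The expected step is a 2.8-fold higher number from compound 2 to compound 4 (0.45 log units; beyond the scatter).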

Compound 4, half-maximal effective concentration: 173 nM
Compound 4: middle estimate off by 1.2-fold (0.06 log units), on the high side; the measured number falls inside the stated range.
By their numbers in this assay, from the lowest: compounds 2, 1, 4 and 3 (each within the scatter of the next, the first and the last beyond it).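

Within the data shown here, replacing 2-(3-fluorophenyl)ethenyl with 3-ethoxyphenyl gives a 2.4-fold higher number from compound 2 to compound 4 (0.39 log units; beyond the scatter), so the double bond outside the aromatic rings, present in all the earlier compounds, can be lost at only a modest cost. The exchange keeps the heavy-atom count but alters several features at once, so the data cannot assign the rise to any one of them. No measurement here explains the rise. As far as these compounds go, it remains open how a methoxy or propoxy group in place of ethoxy, or a directly attached 3-fluorophenyl, would compare with compound 4.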